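This account rests on a few compounds, and the source may have more. Where it says the series, first, only, none or still open, it means among the compounds named here.

In a functional assay on T-24 cells (Homo sapiens) for antiproliferative activity (on this read-out higher numbers stand for weaker inhibition and lower numbers for stronger inhibition), compound 1 `N=C(N)N/N=C/c1cccc(C(=N)N)c1` gives 9100 nM and compound 2 `N=C(NN)N/N=C/c1cccc(C(=N)N)c1` gives 25000 nM as the higher of the two numbers. Compound 3 `CCCCNC(=N)N/N=C/c1cccc(C(=N)N)c1` differs from compound 2 by butyl in place of amino on an amine nitrogen and is not yet measured. Among the compounds with values here, the one measured step that bears on this, a 2.7-fold higher number from compound 1 to compound 2 (0.44 log units; beyond the scatter) when amino replaced hydrogen on an amine nitrogen, was modest. Losing the amino may reverse part of that step, though butyl itself is untested. A modest step to a lower number is therefore expected, namely a 2.1-fold lower number from compound 2 to compound 3 (0.32 log units; beyond the scatter) in this estimate. The expected value for compound 3 is 12000 nM within an estimated range of 3500 nM to 40000 nM on this read-out.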

Compound 3, half-maximal inhibitory concentration: > 26800 nM
Compound 3 was reported as a limit (the forecaster's own chance of this, stated with the estimate: 5%); at least 2.2-fold (0.34 log units) between middle value and limit.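

The value for compound 3 is a limit and not a number: the limit of > 26800 nM in this assay, at which 1 of the 3 values shown sits. In this assay, butyl in place of hydrogen on the amine nitrogen gives an at least 2.9-fold higher number from compound 1 to compound 3 (0.46 log units; beyond the scatter), so both amino and butyl at this position now give higher numbers than hydrogen. Against amino, the reading is an at least 1.0-fold higher number from compound 2 to compound 3 (0.03 log units; that floor lies within the scatter), which cannot separate butyl from amino. Still open, from the compounds shown here alone, is where the true number of compound 3 lies, and whether a smaller group such as methyl on this nitrogen would stay close to compound 1.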